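Swapping the Chlorobenzyl Arm for a Cyclohexyl Ring

The source may hold more compounds than are shown below. What is called first, only, known or untested is meant among the compounds shown, and "the series" means these compounds.

Compound 1, `O=C(O)c1ccccc1-c1ccc(CCc2ncc(Cc3ccccc3F)[nH]2)cc1`: 9.5 nM
Compound 2, `N#Cc1ccccc1Cc1cnc(CCc2ccc(-c3ccccc3C(=O)O)cc2)[nH]1`: 642 nM
Compound 3, `O=C(O)c1ccccc1-c1ccc(CCc2ncc(Cc3ccccc3Cl)[nH]2)cc1`: 22 nM

All three compounds share one core and differ only in the group on the benzyl ring. In an in vitro functional assay on cells for agonist activity at Bombesin receptor subtype-3 (Mus musculus), read by luminescence and calcium flux (a lower number here means that less compound is needed, a higher number that more compound is needed for the effect), compound 3 gives 22 nM, the second highest of the three numbers. Its nearer neighbour is separated from it by a 2.3-fold higher number from compound 1 to compound 3 (0.36 log units; beyond the scatter), its farther neighbour by a 29-fold lower number from compound 2 to compound 3 (1.47 log units; beyond the scatter).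

Compound 4, `O=C(O)c1ccccc1-c1ccc(CCc2ncc(C3CCCCC3)[nH]2)cc1`, is not yet measured. Its change from compound 3 is cyclohexyl in place of 2-chlorobenzyl on an aromatic carbon. Among the measured compounds shown here, no measured step removes the aromatic ring itself; the three known steps only exchange one small group on that ring for another. Still, they show how responsive this part of the molecule is: a 68-fold higher number from compound 1 to compound 2 (1.83 log units; beyond the scatter) was large, while a 2.3-fold higher number from compound 1 to compound 3 (0.36 log units; beyond the scatter) was modest, so even small edits here move the number well beyond the scatter. Removing the whole aromatic ring and its chlorine in favour of a saturated ring is a bigger edit than any of those, and the direction is uncertain.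

For compound 4 the estimate is 120 nM, within the range 15 nM to 900 nM, which corresponds to the expected step of a 5.5-fold higher number from compound 3 to compound 4 (0.74 log units; beyond the scatter).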

Compound 4, half-maximal effective concentration: 14.7 nM
Beside the measured number, compound 4's estimate is 8.2-fold (0.91 log units) above it; the measured number lies below the stated range.
By their numbers in this assay, from the lowest: compounds 1, 4 and 3 (each within the scatter of the next, the first and the last beyond it); then compound 2.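

In this assay, an aromatic ring in this arm is not required for a low number among these compounds: replacing 2-chlorobenzyl with the non-aromatic cyclohexyl gives a 1.5-fold lower number from compound 3 to compound 4 (0.18 log units; within the scatter), and the comparison with the 2-fluorobenzyl arm gives a 1.5-fold higher number from compound 1 to compound 4 (0.19 log units; within the scatter). The position therefore accepts a saturated carbon ring as well as these two halogen-bearing benzyl groups, even though the entering group has fewer heavy atoms and no chlorine or fluorine. The 2-cyanobenzyl arm of compound 2 is the exception among the four, with a 44-fold lower number from compound 2 to compound 4 (1.64 log units; beyond the scatter), and nothing available explains why these arms compare as they do.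

A cyclohexylmethyl group would show whether the carbon link of the benzyl arms matters once the ring is saturated, while cyclopentyl or an unsubstituted benzyl group would test how far ring size and the halogen can vary. From the compounds shown here alone, whether an amine or a hydroxyl group on the cyclohexyl ring would be accepted, or would produce a step as large as the one seen with the nitrile, remains open.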